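The compounds below may be only part of what the source reports. "The series", "measured", "known", "first", "only" and "open" are said of these compounds alone.

Compound 1 `O=C(O)c1cnc(-c2ccccc2[N+](=O)[O-])[nH]c1=O` carries a nitro group on its outer ring. In a functional assay on the whole organism (strain Sprague-Dawley) for inhibition, with Rattus norvegicus as the target, with a stated time of 10 min (on this read-out higher numbers stand for an effect only at larger amounts of compound and lower numbers for an effect already at smaller amounts), compound 1 gives > 50 mg/kg, which is a limit of the measurement rather than a number. Compound 2 `Nc1ccccc1-c1ncc(C(=O)O)c(=O)[nH]1` gives 50 mg/kg in this assay. The step of a number no higher from compound 1 to compound 2 (the limit leaves the size open) cannot be sized, because the limit of > 50 mg/kg in this assay, at which 1 of the 3 values shown sits, is all that compound 1 shows. Compound 3 `CCOc1ccc([N+](=O)[O-])cc1-c1ncc(C(=O)O)c(=O)[nH]1` gives 25 mg/kg in this assay; the difference between the cores of compound 1 and compound 3 is not broken down here. Compound 4 `CCOc1ccc(N)cc1-c1ncc(C(=O)O)c(=O)[nH]1` is not yet measured. The change amino in place of nitro on an aromatic carbon is the same kind of change as amino in place of nitro on an aromatic carbon, though here the place is meta to a large group and para to an ethoxy group, where before it was ortho to a large group. Compound 4 is expected to give about 30 mg/kg in this assay. That expectation means a step of a 1.2-fold higher number from compound 3 to compound 4 (0.08 log units; within the scatter), and it rests on compound 3 at 25 mg/kg and on the open size of a number no higher from compound 1 to compound 2 (the limit leaves the size open).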

Compound 4, dose for 50% inhibition: 1.2 mg/kg
Estimate against measurement, compound 4: 25-fold (1.40 log units) above; measured number below the stated range.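

In this assay, amino in place of nitro on an aromatic carbon gives a 21-fold lower number from compound 3 to compound 4 (1.32 log units; beyond the scatter), so on this core the change lowers the dose needed by a large margin. Set beside the same change on the other core, the comparison stays unsettled: the same change on two cores in this assay, a number no higher (the limit leaves the size open) from compound 1 to compound 2 and a 21-fold lower number (1.32 log units; beyond the scatter) from compound 3 to compound 4; the limit leaves it open whether they differ. The result therefore shows that the change can work strongly on one core, but not that this size carries over to another, and the earlier step cannot be read, as compound 1 shows only a limit: the limit of > 50 mg/kg in this assay, at which 1 of the 4 values shown sits.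

Open, as far as these compounds go, is how a methylamino or acetylamino group would compare with amino in the same place. Also open, from the compounds shown here alone, is whether the size of the step depends on the ethoxy group, which a methoxy group or a plain hydrogen in its place could test.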